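Fluoro for Hydrogen on a Pendant Phenyl: Cytotoxicity Notes

The compounds below may be only part of what the source reports. "The series", "measured", "known", "first", "only" and "open" are said of these compounds alone.

compound 1 `CC(=O)c1cc(-c2ccccc2)cc2cc(-c3ccc(F)cc3)[nH]c12`: > 100000 nM
compound 2 `CC(=O)c1cc(-c2ccc(F)cc2)cc2cc(-c3ccc(F)cc3)[nH]c12`: 87400 nM
compound 3 `CC(=O)c1cc(/C=C/c2ccccc2)cc2cc(-c3ccccc3)[nH]c12`: > 100000 nM

All values come from a functional assay on MCF7 cells (Homo sapiens) for cytotoxicity, read by MTT assay, with a stated time of 2 days; on this read-out higher numbers stand for lower toxicity in this test and lower numbers for higher toxicity in this test. For compound 1 the entry is a limit of the assay, not a number. Compound 3 likewise reports only a limit. Compound 2 differs from compound 1 by fluoro in place of hydrogen on an aromatic carbon; this gave an at least 1.1-fold lower number from compound 1 to compound 2 (0.05 log units; that floor lies within the scatter). The difference between the cores of compound 1 and compound 3 is not broken down here. Compound 4 `CC(=O)c1cc(/C=C/c2ccc(F)cc2)cc2cc(-c3ccccc3)[nH]c12`, not yet measured, differs from compound 3 by fluoro in place of hydrogen on an aromatic carbon, the same change at the same place as before. For compound 4 the expected step is a number no higher from compound 3 to compound 4 (the limit leaves the size open), resting on an at least 1.1-fold lower number from compound 1 to compound 2 (0.05 log units; that floor lies within the scatter). Because compound 3 sits at the limit of > 100000 nM in this assay, at which 2 of the 3 values shown sit, compound 4 may well also return only a limit. Compound 4 is expected at about 100000 nM, between 50000 nM and 250000 nM.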

Compound 4, concentration lethal to 50% of the cells: 18500 nM
For compound 4 the middle estimate is 5.4-fold (0.73 log units) above the measured one; measured number outside the range, below it.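

In this assay, the change from 2-phenylethenyl to 2-(4-fluorophenyl)ethenyl gives an at least 5.4-fold lower number from compound 3 to compound 4 (0.73 log units; beyond the scatter). On this core the lower number lies beyond the scatter, whereas on the core of compound 1 only a floor within the scatter can be read, so the result supports carrying the change across but does not fix its size on either core. Both steps start from a limit, and whether the change is worth more on one core than on the other is not shown: the same change on two cores in this assay, an at least 1.1-fold lower number (0.05 log units; that floor lies within the scatter) from compound 1 to compound 2 and an at least 5.4-fold lower number (0.73 log units; beyond the scatter) from compound 3 to compound 4; the limit leaves it open whether they differ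

The compounds shown leave open whether chloro, methoxy or a nitrile at the same place would give a similar result. Also open, as far as these compounds go, is the size of the fluoro step on a core whose hydrogen parent returns a number rather than a limit.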